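Dimethylamino Replacing an Ester Side Chain on the Core

The compounds below may be only part of what the source reports. "The series", "measured", "known", "first", "only" and "open" are said of these compounds alone.

Of the compounds shown here, three sharing one core have been measured in a physicochemical assay for lipophilicity, at pH 7.4; a higher number here means a more lipophilic compound, a lower number a more polar compound. Compound 1 `CC(C)Nc1nc(NCc2ccco2)c2ccccc2n1` gives 3.15, compound 2 `OCCNc1nc(NCc2ccco2)c2ccccc2n1` gives 2.19, and compound 3 `CCOC(=O)CNc1nc(NC(C)C)nc2ccccc12` gives 2.54. Compound 3 thus stands second highest of the three: its number lies beyond the scatter above that of compound 2 and beyond the scatter below that of compound 1. Two single-point changes have been measured within this set: a number 0.96 log units lower from compound 1 to compound 2 (beyond the scatter), and a number 0.61 log units lower from compound 1 to compound 3 (beyond the scatter).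

Compound 4 `CC(C)Nc1nc(N(C)C)c2ccccc2n1` is next to be measured. dimethylamino in place of ((ethoxycarbonyl)methyl)amino on an aromatic carbon The ((ethoxycarbonyl)methyl)amino group with its one hydrogen-bond donor and three acceptors departs, and dimethylamino with no donor and one acceptor takes its place. Among the measured compounds shown here, no measured step covers this exact swap. The closest guide is a number 0.61 log units lower from compound 1 to compound 3 (beyond the scatter), where bringing ethoxycarbonyl in lowered the number; taking it out again should push the other way, though dimethylamino is far smaller than furan-2-yl, so compound 4 is not expected to reach compound 1. A modest rise beyond the scatter is expected, a number 0.36 log units higher from compound 3 to compound 4 (beyond the scatter). Compound 4 is therefore estimated at 2.9, within a range from 2.4 to 3.4.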

Compound 4, distribution coefficient: 3.13
For compound 4 the middle estimate is 0.23 log units below the measured one; the range from low to high includes it.
By their numbers in this assay, from the lowest: compound 2; then compound 3; then compounds 4 and 1 (each within the scatter of the next).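

On the aromatic carbon opposite the ring nitrogen, this assay records a number 0.59 log units higher from compound 3 to compound 4 (beyond the scatter) when dimethylamino replaces ((ethoxycarbonyl)methyl)amino, so this swap gives a modest step beyond the scatter. The earlier compounds shown here showed ethoxycarbonyl only against furan-2-yl on the saturated chain carbon, whereas the new result adds a second comparison at the same place: with dimethylamino in place of ((furan-2-yl)methyl)amino, there is a number 0.02 log units lower from compound 1 to compound 4 (within the scatter), so this assay does not separate these two groups even though only the second carries a ring. No measurement shown here explains either step, and the structures alone give no way to assign one feature of the departing groups as the source of the difference.

Still open, as far as these compounds go, is how this number responds when the group at this place is a plain amino group, a morpholine ring or a (carboxymethyl)amino group, which would test the same place with quite different atoms. Also open, from the compounds shown here alone, is whether the match between compound 1 and compound 4 would hold with a longer chain, such as diethylamino, in place of dimethylamino.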